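This account rests on a few compounds, and the source may have more. Where it says the series, first, only, none or still open, it means among the compounds named here.

Measured so far:
Compound 1 `COc1cc(-n2ncnc2-c2ccc(C)cc2)cc(OC)c1OC`: 540 nM
Compound 2 `COc1cc(-c2ncnn2-c2ccc(Cl)cc2Cl)cc(OC)c1OC`: > 10000 nM (a limit of the assay)

Going by the values given here, in a functional assay on MCF7 cells (Homo sapiens) for antiproliferative activity, read by MTT assay, with a stated time of 72 h (a lower number here means a stronger inhibitor, a higher number a weaker inhibitor), compound 1 gives 540 nM, the only true number available so far. Compound 2 is recorded at > 10000 nM, which is a limit and not a number.

Compound 3 `COc1cc(-n2ncnc2-c2ccc(Cl)cc2)cc(OC)c1OC` has not yet been measured. It keeps the core of compound 1 but carries chloro in place of methyl on an aromatic carbon, para to a large group, a change from 4-methylphenyl to 4-chlorophenyl: chloro in place of methyl on an aromatic carbon.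

Among the compounds with values here, no measured step of this kind exists to guide the judgement. In this assay, only a small step toward weaker inhibition is expected, and a result within the scatter would be no surprise. The estimated step of a 1.7-fold higher number from compound 1 to compound 3 (0.22 log units; within the scatter) is therefore modest. For compound 3 the expected value is 900 nM, with an estimated range of 200 nM to 4000 nM.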

Compound 3, half-maximal inhibitory concentration: > 10000 nM
Compound 3: only a limit was reported; the forecaster's own chance of this, stated with the estimate: 8%; middle value at least 11-fold (1.04 log units) from the limit.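

In this assay, the 4-chlorophenyl group does not stand in for the 4-methylphenyl group: chloro in place of methyl on an aromatic carbon, para to a large group, gives an at least 18-fold higher number from compound 1 to compound 3 (1.26 log units; beyond the scatter). Going by these compounds alone, this shows that the activity of the core of compound 1 is sensitive to a change of a single heavy atom at this position, which the earlier compounds, differing in more than one place, could not show. As far as these compounds go, the result for compound 3 is a limit of the assay and not a number, so the true size of the step stays unknown: the limit of > 10000 nM in this assay, at which 2 of the 3 values shown sit.

The compounds shown leave open whether any other group at this position, such as ethyl, methoxy or an amine, keeps the activity in this assay. They also leave open whether fluoro behaves like chloro or like methyl here.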